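Pannexin-1 inhibition series: removing a benzylic ring carboxy

This account rests on a few compounds, and the source may have more. Where it says the series, first, only, none or still open, it means among the compounds named here.

Measured so far:
compound 1 `O=C(O)c1cc2cc([N+](=O)[O-])ccc2n1Cc1ccccc1` — 51.3%
compound 2 `NS(=O)(=O)c1ccc2c(c1)cc(C(=O)O)n2Cc1ccc(C(=O)O)cc1` — 61.7%

Among the compounds with values here, in an assay on cells (Oocyte) for inhibition of pannexin-1 (Mus musculus), read by voltage clamp, tested at 50 uM, in the presence of a further agent that is not named here (a lower number here means less inhibition, a higher number more inhibition at the concentration tested (going by the name of the read-out)), compound 2 gives 61.7%, the higher of the two numbers; compound 1 sits lower by a gap beyond the usual scatter, but the two structures differ in several places, so no single step can be drawn between them.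

Compound 3 `NS(=O)(=O)c1ccc2c(c1)cc(C(=O)O)n2Cc1ccccc1` is the next compound for this assay. Against compound 2 the change is hydrogen in place of carboxy on an aromatic carbon, on an aromatic carbon of a six-membered aromatic ring of carbon only.

Within the data shown here, no comparable step has been measured, so the expected step from compound 2 to compound 3 is a modest drop, a number 13.7 percentage points lower from compound 2 to compound 3 (beyond the scatter), with a result near or within the scatter not excluded. For compound 3 the estimate in this assay is 48%, ranging from 30% to 65%.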

Compound 3, a percentage reported as inhibition, at one concentration (the size of the read-out at that concentration, not a potency): 29.3%
Compound 3: the middle estimate sits 18.7 percentage points above what was measured, outside the stated range (below it).
By their numbers in this assay, from the lowest: compound 3; then compound 1; then compound 2.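

In this assay, hydrogen in place of carboxy para to a large group gives a number 32.4 percentage points lower from compound 2 to compound 3 (beyond the scatter), so this position is sensitive to the change. Sulfamoyl in place of nitro gives a number 22 percentage points lower from compound 1 to compound 3 (beyond the scatter), which leaves compound 3 lowest of the three and shows that sulfamoyl without the carboxy does not retain the level of compound 2. Nothing available explains either step.

Open, on these data alone, is whether an amine or a methyl ester at this aromatic carbon would retain the inhibition seen with carboxy. Also open, as far as these compounds go, is how nitro would behave with that carboxy present.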